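The source may hold more compounds than are shown below. What is called first, only, known or untested is meant among the compounds shown, and "the series" means these compounds.

Compound 1 `NCCCCN(C[C@@H]1Cc2ncccc2CN1)[C@H]1CCCc2cccnc21`: 98%
Compound 2 `CN(C[C@H]1Cc2ncccc2CN1)[C@H]1CCCc2cccnc21`: 95%

In an ADME assay on microsomes from liver (Homo sapiens) for metabolic stability, using NADPH, with a stated time of 10 min (a lower number here means that less of the compound is left, a higher number that more of the compound is left), compound 2 gives 95%, within the usual scatter of compound 1, so the two stand level. Compound 3 `CN(C[C@@H]1Cc2ncccc2CN1)[C@H]1CCCc2cccnc21` has the same atoms and bonds as compound 2 and differs only in configuration as drawn the two compounds have the same atoms and bonds and differ only in configuration as drawn: 1 of 2 stereo elements differ; a stereocentre at a saturated ring carbon is drawn R in compound 2 and S in compound 3: a stereocentre at a saturated ring carbon is drawn R in compound 2 and S in compound 3. For the measured compounds named here, no measured pair shows this change alone, so the expectation rests on the values of compound 1 and compound 2. The step of a number 1 percentage points lower from compound 2 to compound 3 (within the scatter) is expected to stay within the scatter. For compound 3 the estimated value is 94%, with an expected range of 84% to 100%.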

Compound 3, percent of the compound remaining: 100%
Compound 3: middle estimate off by 6 percentage points, on the low side, and the stated range covers the measured number.
By their numbers in this assay, from the lowest: compounds 2, 1 and 3 (each within the scatter of the next).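

The comparison of compound 2 with compound 3 isolates one stereocentre at a saturated ring carbon, and in this assay the two stand level, with a number 5 percentage points higher from compound 2 to compound 3 (within the scatter). Hydrogen in place of 3-aminopropyl also leaves the result within the scatter, with a number 2 percentage points higher from compound 1 to compound 3 (within the scatter). The first comparison therefore concerns configuration alone: the fact that compounds 2 and 3 differ only in the configuration as drawn

All these values lie close together, so neither change shows any measurable effect here. From the compounds shown here alone, whether a carboxylic acid or a longer chain in place of 3-aminopropyl would keep the compound as well remains open.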